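Inverting one stereocentre: compound 2 and compound 3

The source may hold more compounds than are shown below. What is called first, only, known or untested is meant among the compounds shown, and "the series" means these compounds.

- compound 1 `Cc1cn([C@H]2C[C@H](CC3=CC(=O)C(=O)C=C3)[C@@H](CO[Si](C)(C)C(C)(C)C)O2)c(=O)[nH]c1=O`: no result reported
- compound 2 `COc1ccc(C2([C@H]3C[C@H](n4cc(C)c(=O)[nH]c4=O)O[C@@H]3CO[Si](C)(C)C(C)(C)C)SCCCS2)cc1OC`: 2290 nM

Among the measured compounds shown here, in a functional assay on MKN-7 cells (Homo sapiens) for inhibition, read by sulforhodamine B assay, with a stated time of 48 h (on this read-out higher numbers stand for weaker inhibition of growth and lower numbers for stronger inhibition of growth), compound 2 gives 2290 nM as the only number available, and compound 1 has no reported result, so compound 2 cannot be ranked against anything. Compound 3 `COc1ccc(C2([C@H]3C[C@@H](n4cc(C)c(=O)[nH]c4=O)O[C@@H]3CO[Si](C)(C)C(C)(C)C)SCCCS2)cc1OC` is its stereoisomer: the two compounds have the same atoms and bonds and differ only in configuration as drawn: 1 of 3 stereo elements differ; a stereocentre at a saturated ring carbon is drawn R in compound 2 and S in compound 3 and a stereocentre at a saturated ring carbon is drawn R in compound 2 and S in compound 3. For the measured compounds named here, no measured step exists to guide this, and the estimated shift a 1.3-fold higher number from compound 2 to compound 3 (0.12 log units; within the scatter) is expected to stay within the scatter. In this assay compound 3 is expected at 3000 nM (estimated range 1000 nM to 9000 nM).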

Compound 3, concentration for 50% growth inhibition: 3020 nM
Compound 3: the middle estimate sits 1.0-fold (0.00 log units) below what was measured; low and high end bracket the measured number.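

Among the compounds shown here, at this position, the inversion of a saturated ring carbon gives the first measured step in this assay, a 1.3-fold higher number from compound 2 to compound 3 (0.12 log units; within the scatter), so the drawn configuration there does not separate the two compounds on this read-out. The comparison isolates that one stereocentre, as nothing else sets the pair apart: the fact that compounds 2 and 3 differ only in the configuration as drawn. As far as these compounds go, whether configuration at this carbon would still make so little difference with a free hydroxyl or an amine in place of the silyl ether stays open. The compounds shown also leave open how either configuration would read with a carboxylic acid on the dimethoxyphenyl group.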